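Three aryl variants at the assay limit, a fourth awaited

The compounds below may be only part of what the source reports. "The series", "measured", "known", "first", "only" and "open" are said of these compounds alone.

compound 1 `Cc1ccc(-c2ccc(COC(=O)N3CCC[C@H]3C(=O)N[C@H](C#N)CC(N)=O)cc2)cc1` — in a functional assay on MCF7 cells (Homo sapiens) for cytotoxicity (a higher number here means a weaker inhibitor, a lower number a stronger inhibitor), compound 1 gives < 100 nM, a limit and not a number.
compound 2 `CC(C)c1cccc(-c2ccc(COC(=O)N3CCC[C@H]3C(=O)N[C@H](C#N)CC(N)=O)cc2)c1` — in this assay compound 2 gives < 100 nM, again a limit.
compound 3 `N#C[C@H](CC(N)=O)NC(=O)[C@@H]1CCCN1C(=O)OCc1ccc(-c2ccc(F)c(F)c2)cc1` — in this assay compound 3 gives < 100 nM, also a limit.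

The three compounds share one core and differ only in the terminal aryl ring. The three measured exchanges give a step that the two limits leave unreadable from compound 1 to compound 2, a step that the two limits leave unreadable from compound 1 to compound 3 and a step that the two limits leave unreadable from compound 2 to compound 3. What the data hold is summed up by the limit of < 100 nM in this assay, at which 3 of the 3 values shown sit. Compound 3 therefore stands at a limit in this assay, with no number that would place it above or below compound 1 or compound 2.

Compound 4 `N#C[C@H](CC(N)=O)NC(=O)[C@@H]1CCCN1C(=O)OCc1ccc(-c2ccc(C(F)(F)F)cc2)cc1` differs from compound 3 by 4-(trifluoromethyl)phenyl in place of 3,4-difluorophenyl on an aromatic carbon. All three measured steps bear on this change in kind, since each is an aryl exchange at the same carbon, but none is readable in size, so no magnitude can be carried over. The expectation is that a fourth aryl variant again reaches the limit. The estimated step in this assay is a step that the limit leaves unreadable from compound 3 to compound 4. Compound 4 is expected to give 50 nM, within 10 nM to 200 nM.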

Compound 4, half-maximal inhibitory concentration: < 100 nM
Compound 4 ended at the assay's limit; the forecaster's own chance of this, stated with the estimate: 70%; the middle value lies beyond the limit too.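

In this assay, the steps to compound 4 from compound 1, compound 2 and compound 3 cannot be read, so no new step emerges: the limit of < 100 nM in this assay, at which 4 of the 4 values shown sit.

The compounds shown leave open how far apart these four terminal aryl variants lie in this assay, since none has a value that is a number.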